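A few compounds are considered here, and "the series" means these few. Any claim that something is new, unique, unknown or untested is made for them only; others in the source may bear on it.

Measured in a functional assay on DU-145 cells (Homo sapiens) for inhibition, read by trypan blue exclusion, with a stated time of 96 h; on this read-out higher numbers stand for weaker inhibition of growth and lower numbers for stronger inhibition of growth:
Compound 1 `CSc1ccc(/C=C(\C(=O)c2ccc(Cl)cc2)S(=O)(=O)Cc2ccc(C)cc2)cc1`: 10000 nM
Compound 2 `Cc1ccc(CS(=O)(=O)/C(=C/c2cc(C)cc(C)c2)C(=O)c2ccc(Cl)cc2)cc1`: 10000 nM
Compound 3 `CCOc1ccc(/C=C(\C(=O)c2ccc(Cl)cc2)S(=O)(=O)Cc2ccc(C)cc2)cc1OC`: 10000 nM

Level with compound 1 and compound 2, compound 3 stands at 10000 nM. Compound 4 `CCOc1ccc(/C=C(/SCc2ccc(F)cc2)C(=O)c2ccc(Cl)cc2)cc1OC` differs from it in one place: (4-fluorobenzyl)sulfanyl in place of (4-methylbenzyl)sulfonyl on a double-bonded chain carbon bound to a carbonyl carbon and a double-bonded chain carbon. For the measured compounds named here, no measured step touches this place. The steps available exchange a different group, no change at the digits printed from compound 1 to compound 3 (within the scatter) and no change at the digits printed from compound 2 to compound 3 (within the scatter), and both lie within the scatter. On this thin evidence, no change beyond the scatter is expected in this assay. The expected step is a 1.4-fold lower number from compound 3 to compound 4 (0.15 log units; within the scatter). For compound 4 the estimated value is 7000 nM, with an expected range of 1500 nM to 15000 nM.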

Compound 4, concentration for 50% growth inhibition: 1000 nM
Estimate against measurement, compound 4: 7.0-fold (0.85 log units) above, outside the stated range (below it).
By their numbers in this assay, from the lowest: compound 4; then compounds 1, 2 and 3 (each within the scatter of the next).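

In this assay the position on a double-bonded chain carbon bound to a carbonyl carbon and a double-bonded chain carbon proves responsive: (4-fluorobenzyl)sulfanyl in place of (4-methylbenzyl)sulfonyl gives a 10-fold lower number from compound 3 to compound 4 (1.00 log units; beyond the scatter) and so stronger inhibition of growth. The earlier exchanges of the aryl group at the other double-bonded chain carbon moved nothing at the digits printed. No measurement at hand explains this step. On these data alone, the sulfur link and the ring substituent changed together, so their shares stay open. Neither (4-methylbenzyl)sulfanyl nor (4-fluorobenzyl)sulfonyl stands among the compounds shown to separate them.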